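The source may report more compounds than this note shows. Statements on the series, on what has been measured and on what is new or still open speak of the compounds shown alone.

Measured in a functional assay on HL-60 cells (Homo sapiens) for inhibition; on this read-out higher numbers stand for weaker inhibition and lower numbers for stronger inhibition:
- Compound 1 `CCn1nc(-c2ccc(OC)cc2)c(-c2ccc(OC)cc2)cc1=O`: 610 nM
- Compound 2 `COc1ccc(-c2cc(=O)n(CC3CCCC3)nc2-c2ccc(OC)cc2)cc1`: 110 nM

Of these two compounds, compound 2 has the lower number, 110 nM, and so the stronger inhibition. Among the measured compounds shown here, the next compound, compound 3 `C=CCn1nc(-c2ccc(OC)cc2)c(-c2ccc(OC)cc2)cc1=O`, keeps the shared core and alters only one group: vinyl in place of cyclopentyl on a saturated chain carbon bound to an aromatic nitrogen. In words, this is vinyl in place of cyclopentyl on a saturated chain carbon bound to an aromatic nitrogen, or cyclopentylmethyl to allyl when cut one bond further out.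

For the measured compounds named here, only one measured step bears on this change. It sits at the same place and shows a 5.5-fold lower number from compound 1 to compound 2 (0.74 log units; beyond the scatter), with cyclopentyl in place of methyl. Vinyl has fewer carbons than cyclopentyl but more than methyl, so compound 3 is expected to fall between the two measured compounds. With just two measured compounds, this expectation is loose. The expected change is a 2.7-fold higher number from compound 2 to compound 3 (0.44 log units; beyond the scatter), which would give back part of the earlier step. For compound 3 the estimated value is 300 nM, with an expected range from 100 nM to 900 nM.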

Compound 3, half-maximal inhibitory concentration: > 100000 nM
Compound 3: no number, only a limit (the forecaster's own chance of this, stated with the estimate: 3%); at least 330-fold (2.52 log units) between middle value and limit.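

In this assay compound 3 gives > 100000 nM, which is a limit of the assay and not a number, so only a bound on its inhibition is known. The change at this place has a large effect, with an at least 900-fold higher number from compound 2 to compound 3 (2.95 log units; beyond the scatter) and an at least 160-fold higher number from compound 1 to compound 3 (2.21 log units; beyond the scatter), so inhibition here does not simply track the size of the group: allyl, cut one bond further out, lies far on the weak side of both the smaller ethyl group of compound 1 and the larger cyclopentylmethyl group of compound 2. This large drop comes from a single small change on the shared core, and the size of the steps is bounded by the value at which the assay stops: the limit of > 100000 nM in this assay, at which 1 of the 3 values shown sits.

The compounds shown cannot separate the effect of the double bond in allyl from that of the chain it sits on, and a saturated propyl chain would bear directly on that question. From the compounds shown here alone, how far inhibition can be improved also stays open, since it is unknown whether a cyclohexylmethyl group, a benzyl group or a chain ending in an amine would match compound 2.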